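Replacing the oxygen-linked group of compound 2

The source may hold more compounds than are shown below. What is called first, only, known or untested is meant among the compounds shown, and "the series" means these compounds.

Compound 1 `CNC(=O)c1cc(Oc2ccc(Nc3nccc(N4CCCC4)n3)cc2)ccn1`: 3410 nM
Compound 2 `c1cc(N2CCCCC2)nc(Nc2ccc(Oc3ncnc4sccc34)cc2)n1`: 4020 nM

Both numbers come from a functional assay on A549 cells (Homo sapiens) for inhibition, read by MTT assay, with a stated time of 72 h; a lower number here means a stronger inhibitor, a higher number a weaker inhibitor. For the measured compounds named here, compound 2 stands level with compound 1, the only other compound measured so far, as their two values lie within the usual scatter of each other. Neither compound can be ranked above the other.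

The next compound to be measured is compound 3 `CNC(=O)c1cc(Oc2ccc(Nc3nccc(N4CCCCC4)n3)cc2)ccn1`. It differs from compound 2 on an oxygen on an aromatic ring: a group of 10 heavy atoms (7 carbon, 2 nitrogen, 1 oxygen; one six-membered aromatic ring with 1 hetero atom) in place of a group of 9 heavy atoms (6 carbon, 2 nitrogen, 1 sulfur; one five-membered aromatic ring with 1 hetero atom, one six-membered aromatic ring with 2 hetero atoms), on an oxygen on an aromatic ring. Going by the values given here, no measured pair isolates this change, so its size in this assay has no direct support. Among the compounds with values here, the only indirect guide is that the entering 2-(methylcarbamoyl)pyridin-4-yl group is already carried by compound 1, which gives 3410 nM. On that basis, no step beyond the scatter is expected, and no direction is favoured. The estimate for the change is a 1.1-fold lower number from compound 2 to compound 3 (0.05 log units; within the scatter). Compound 3 is expected at 3600 nM, with an estimated range of 1500 nM to 8500 nM.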

Compound 3, half-maximal inhibitory concentration: 890 nM
The estimate for compound 3 lay 4.0-fold (0.61 log units) above the measured number, outside the stated range (below it).
By their numbers in this assay, from the lowest: compound 3; then compounds 1 and 2 (each within the scatter of the next).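

In this assay, 2-(methylcarbamoyl)pyridin-4-yl in place of the group of compound 2 with its five-membered and six-membered aromatic rings, on an oxygen on an aromatic ring, gives a 4.5-fold lower number from compound 2 to compound 3 (0.65 log units; beyond the scatter), so the group at this oxygen does change the read-out when the rest of the molecule is held fixed. With 2-(methylcarbamoyl)pyridin-4-yl kept, piperidin-1-yl in place of pyrrolidin-1-yl on an aromatic carbon gives a 3.8-fold lower number from compound 1 to compound 3 (0.58 log units; beyond the scatter), so the level standing of compound 1 and compound 2, which differ in both places, did not mean that either place was without effect. Nothing at hand accounts for either step.

As far as these compounds go, each step rests on a single pair ending at compound 3, so whether the two changes act independently or depend on each other remains open. Also open, from the compounds shown here alone, is whether morpholin-4-yl or an open-chain dimethylamino group on that aromatic carbon, or a carboxylic acid in place of the methylcarbamoyl group on the pyridine, would keep the lower number.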